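The source may hold more compounds than are shown below. What is called first, only, known or untested is meant among the compounds shown, and "the series" means these compounds.

Measured so far:
compound 1 `COc1c(C(C)(C)C)cc(-n2ccc(=O)[nH]c2=O)c2ncc(-c3ccc(NS(C)(=O)=O)cc3)cc12`: 7.9 uL/min
compound 2 `COc1c(C(F)(F)F)cc(-n2ccc(=O)[nH]c2=O)c2ncc(-c3ccc(NS(C)(=O)=O)cc3)cc12`: 1.5 uL/min

In an ADME assay on cells (Hepatocyte, Homo sapiens) for metabolic stability (on this read-out lower numbers stand for slow clearance and higher numbers for fast clearance), compound 2 gives 1.5 uL/min, the lowest of the two numbers, while compound 1 gives 7.9 uL/min. For the measured compounds named here, the single measured step is a 5.3-fold lower number from compound 1 to compound 2 (0.72 log units; beyond the scatter). Compound 3 `COc1c(CC(F)(F)F)cc(-n2ccc(=O)[nH]c2=O)c2ncc(-c3ccc(NS(C)(=O)=O)cc3)cc12` differs from compound 2 by 2,2,2-trifluoroethyl in place of trifluoromethyl on an aromatic carbon. Going by the values given here, no measured step covers this exact change, and the one step recorded bears on it only indirectly, so the expectation is uncertain. Compound 3 is expected to sit between the two measured values, a step of a 2.0-fold higher number from compound 2 to compound 3 (0.30 log units; within the scatter). Compound 3 is estimated at 3 uL/min, range 1.2 uL/min to 8 uL/min.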

Compound 3, intrinsic clearance in a liver preparation (reported as CLH), per the amount of preparation that the assay uses: 0.8 uL/min
The estimate for compound 3 lay 3.8-fold (0.57 log units) above the measured number, and the stated range ends above it.
By their numbers in this assay, from the lowest: compounds 3 and 2 (each within the scatter of the next); then compound 1.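

In this assay, 2,2,2-trifluoroethyl in place of trifluoromethyl gives a 1.9-fold lower number from compound 2 to compound 3 (0.27 log units; within the scatter), so this position tolerates the extra carbon without a step that can be told from the scatter. 2,2,2-Trifluoroethyl in place of tert-butyl gives a 9.9-fold lower number from compound 1 to compound 3 (0.99 log units; beyond the scatter), so a second fluorinated group also stands clear of tert-butyl here. Nothing measured here accounts for these numbers.

Still open, as far as these compounds go, is whether an unfluorinated ethyl, a longer fluorinated chain or an amine at this aromatic carbon would read with compound 1 or with compound 2 and compound 3. Also open, from the compounds shown here alone, is whether these steps carry over when the methanesulfonamide or the uracil-type group of the shared core is replaced.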